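The source may hold more compounds than are shown below. What is called first, only, known or untested is meant among the compounds shown, and "the series" means these compounds.

Measured so far:
compound 1 `COc1cc(OC)c(OC)cc1/C=C/C(=O)c1cc(Cl)ccc1O` — > 150000 nM
compound 2 `COc1cc(OC)c(OC)cc1/C=C/C(=O)c1ccc(Cl)c([N+](=O)[O-])c1` — 16500 nM
compound 3 `COc1cc(OC)c(OC)cc1/C=C/C(=O)c1cccc(C(F)(F)F)c1` — > 150000 nM

These three compounds share a core and differ only in the ring carried by the carbonyl carbon. In a functional assay on HeLa cells (Homo sapiens) for inhibition, read by MTT assay, with a stated time of 72 h (a higher number here means a weaker inhibitor, a lower number a stronger inhibitor), compound 1 gives > 150000 nM, which is a limit of the assay rather than a number. Compound 3 gives > 150000 nM, again a limit. Going by the values given here, compound 2 gives 16500 nM, the only value of the three that is a real number. Compound 1 therefore stands at the limit of > 150000 nM in this assay, at which 2 of the 3 values shown sit, and no ranking among the three can be drawn beyond the fact that compound 2 falls inside the range the assay can read.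

Compound 4 `COc1ccc(C(=O)/C=C/c2cc(OC)c(OC)cc2OC)cc1` has not yet been measured. It differs from compound 1 by 4-methoxyphenyl in place of 5-chloro-2-hydroxyphenyl on a carbonyl carbon. Among the compounds with values here, no step between two measured compounds of this kind is available, so the expectation rests on the three values alone. With two of them at the limit and one within reach, compound 4 is expected to land between those outcomes, and the step of an at least 3.7-fold lower number from compound 1 to compound 4 (0.57 log units; beyond the scatter) is expected to run toward a stronger inhibitor, with its true size left uncertain by the starting limit. Compound 4 is estimated at 40000 nM, within 8000 nM to 150000 nM.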

Compound 4, half-maximal inhibitory concentration: 37600 nM
Estimate against measurement, compound 4: 1.1-fold (0.03 log units) above; the range from low to high includes it.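

On a carbonyl carbon, 4-methoxyphenyl in place of 5-chloro-2-hydroxyphenyl gives an at least 3.9-fold lower number from compound 1 to compound 4 (0.60 log units; beyond the scatter) in this assay and so brings a second compound of this small set inside the range the assay can read. This is the only step shown between two compounds that differ in one place, and it lies beyond the scatter, so the ring on the carbonyl carbon can move the number even though each of the two groups holds 8 heavy atoms. The change also removes the chlorine and the hydrogen-bond donor of compound 1 and adds a methoxy group, and the step does not say which of these matters.

The compounds shown leave open how a ring carrying only the chlorine, only the hydroxyl, or an amine or a carboxylic acid in place of the methoxy group would read at this place. The true size of the step is open as well, as compound 1 in this assay gives > 150000 nM as a limit of the assay and not a number: the limit of > 150000 nM in this assay, at which 2 of the 4 values shown sit.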